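This account rests on a few compounds, and the source may have more. Where it says the series, first, only, none or still open, it means among the compounds named here.

Measured so far in an ADME assay on HEK293 cells (Homo sapiens) for cytotoxicity, read by resazurin assay, with a stated time of 48 h; a higher number here means that more compound is tolerated, a lower number that less compound is tolerated:
compound 1 `O=S(=O)(Nc1ccc2oc(-c3ccccc3)nc2c1)c1cccc(C(F)(F)F)c1` gives > 100000 nM, which is a limit of the assay and not a number.
compound 2 `O=S(=O)(Nc1ccc(-c2nc3ccccc3o2)cc1)c1ccc(Cl)s1` gives > 100000 nM, also a limit.
compound 3 `O=S(=O)(Nc1ccc(-c2nc3ccccc3o2)cc1)c1ccccc1Cl` gives > 100000 nM, also a limit.

Compound 1 therefore does not stand at a measured number in this assay; it sits at the same limit as the two others, and because the limit of > 100000 nM in this assay, at which 3 of the 3 values shown sit, every value shown is a limit, nothing can be read about how the three differ. Among the measured compounds shown here, the one change between measured compounds, 2-chlorophenyl in place of 5-chlorothiophen-2-yl on a sulfonyl sulfur, gives a step that the two limits leave unreadable from compound 2 to compound 3; its size cannot be told.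

Compound 4 `Cc1cccc(S(=O)(=O)Nc2ccc3oc(-c4ccccc4)nc3c2)c1` is still to be measured. It differs from compound 1 in one place: methyl in place of trifluoromethyl on an aromatic carbon.

For the measured compounds named here, no measured step bears on a methyl in place of a trifluoromethyl, and the one step that exists is itself unreadable. Going by the values given here, the only guide is that compound 1 and both other measured compounds sit at the limit, so it is expected that compound 4 will again be tolerated up to the limit rather than show a readable drop. The step of a number no higher from compound 1 to compound 4 (the limit leaves the size open) is expected to be none beyond the scatter. Compound 4 is estimated at 100000 nM, with a range from 30000 nM to 300000 nM.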

Compound 4, half-maximal cytotoxic concentration: 69000 nM
For compound 4 the middle estimate is 1.4-fold (0.16 log units) above the measured one; the measured number falls inside the stated range.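

In this assay, compound 4 is the only compound shown that gives a number rather than a limit, so a change on this aromatic carbon, meta to a large group, can go with a value the assay is able to read. Methyl in place of trifluoromethyl gives an at least 1.4-fold lower number from compound 1 to compound 4 (0.16 log units; that floor lies within the scatter), and as the starting value is only a limit, this figure is a floor: taken alone it stays within the scatter, and the true size of the step remains unknown. This single pair is the only comparison that yields any figure, and the other compounds offer no numbers to set beside it: the limit of > 100000 nM in this assay, at which 3 of the 4 values shown sit.

From the compounds shown here alone, it remains open whether the lower number belongs to methyl in particular or would also appear with another group on this aromatic carbon, such as an amine or a carboxylic acid. It is also open whether the same change would give a readable number on the other cores shown, where only limits stand so far.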